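A few compounds are considered here, and "the series" means these few. Any claim that something is new, unique, unknown or untested is made for them only; others in the source may bear on it.

Of the compounds shown here, three have so far been tested in a functional assay on the whole organism (strain Wistar) for inhibition, with Rattus norvegicus as the target, read by paw edema, with a stated time of 3 h, at a dose of 10 mg/kg by the oral route; a lower number here means less inhibition, a higher number more inhibition at the dose given (going by the name of the read-out). Compound 1 `Cc1ccccc1-n1c(S)nnc1COc1ccc(-c2ccccc2)cc1` is the starting point, and in this assay compound 1 gives 56.8%. Compound 2 `Cc1ccc(-n2c(S)nnc2COc2ccc(-c3ccccc3)cc2)c(C)c1` differs from compound 1 by a single change, (methyl in place of hydrogen on an aromatic carbon), and in this assay compound 2 gives 54.5%. That change made a step of a number 2.3 percentage points lower from compound 1 to compound 2 (within the scatter), so the two values cannot be told apart by this measurement.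

Compound 3 `Cc1ccccc1Nc1nnc(COc2ccc(-c3ccccc3)cc2)s1` is built from the same atoms as compound 1, joined in a different way; the difference between the two cores is not broken down here. In this assay compound 3 gives 25%, the lowest of the three measured values, and its gap to each of the other two lies beyond the usual scatter of the method.

Compound 4 `Cc1ccc(Nc2nnc(COc3ccc(-c4ccccc4)cc3)s2)c(C)c1` has not yet been measured. It stands to compound 3 as compound 2 stands to compound 1, carrying the same change, (methyl in place of hydrogen on an aromatic carbon), at the same kind of place in the ring. Since that change once made a step that stayed within the scatter, compound 4 is expected to stay close to compound 3. Compound 4 is estimated to give 24% in this assay, most likely between 12% and 38%. The step this expectation implies, a number 1 percentage points lower from compound 3 to compound 4 (within the scatter), is estimated to be as small as the one already measured.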

Compound 4, a percentage reported as inhibition, in the whole organism at one dose (the size of the read-out at that dose, not a potency): 56.8%
For compound 4 the middle estimate is 32.8 percentage points below the measured one, outside the stated range (above it).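

In this assay, placing a methyl on the aromatic ring of compound 3 gives a clear rise, a number 31.8 percentage points higher from compound 3 to compound 4 (beyond the scatter), so a change of one carbon atom is enough to move the result a long way on this core. The same change therefore does not carry over from one core to the other with the same effect, and a step measured on the core of compound 1 gave no safe guide to the step on the core of compound 3: the same change on two cores in this assay, a number 2.3 percentage points lower (within the scatter) from compound 1 to compound 2 and a number 31.8 percentage points higher (beyond the scatter) from compound 3 to compound 4, 34.1 percentage points apart, beyond the scatter of two such steps

These two pairs show that the step differs between the cores, but they do not show why it differs, and two pairs at a single dose are too few to support a general rule for the series.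

The compounds shown leave open whether another group at the same place on the ring, such as chloro or methoxy, would also raise the number on the core of compound 3, or whether this rise is particular to methyl. From the compounds shown here alone, each number is also a reading at one dose rather than a potency, so how the two cores compare across a range of doses remains open.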